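The source may hold more compounds than are shown below. What is called first, only, known or untested is meant among the compounds shown, and "the series" means these compounds.

Among the measured compounds shown here, compound 3 `Nc1cccc(C(=O)/C=C/c2ccc3c(c2)B(O)OC3)c1` is the one member of this small set that yields an actual number in an ADME assay on L929 cells (Mus musculus) for cytotoxicity, read by resazurin assay, with a stated time of 72 h (a higher number here means a weaker inhibitor, a lower number a stronger inhibitor), where compound 3 gives 10 ug/mL. Compound 1 `O=C(/C=C/c1ccc2c(c1)B(O)OC2)c1ccc(Br)cc1` reaches only a limit of the assay, giving > 10 ug/mL in this assay. Compound 2 `O=C(/C=C/c1ccc2c(c1)B(O)OC2)c1cccc(F)c1` likewise stops at a limit, giving > 10 ug/mL in this assay. Because of the limit of > 10 ug/mL in this assay, at which 2 of the 3 values shown sit, the steps among these three cannot be sized: a step that the two limits leave unreadable from compound 1 to compound 2 is unreadable, while a number no higher from compound 1 to compound 3 (the limit leaves the size open) and a number no higher from compound 2 to compound 3 (the limit leaves the size open) show only that the number went no higher. Compound 4 `O=C(/C=C/c1ccc2c(c1)B(O)OC2)c1ccccn1` differs from compound 3 by pyridin-2-yl in place of 3-aminophenyl on a carbonyl carbon. For the measured compounds named here, none of the measured steps alters the group on the carbonyl carbon in a readable way, so they offer no direction for compound 4; they show only that every member so far sits at or beyond the same mark. Compound 4 is therefore expected to stay near that mark, with no change at the digits printed from compound 3 to compound 4 (within the scatter) expected to fall within the scatter. The estimate for compound 4 in this assay is 10 ug/mL, spanning from 5 ug/mL to 30 ug/mL.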

Compound 4, half-maximal inhibitory concentration: > 10 ug/mL
Compound 4: a limit, no number; the forecaster's own chance of this, stated with the estimate: 60%; the middle value lies on the limit itself.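

In this assay, pyridin-2-yl in place of 3-aminophenyl on the carbonyl carbon gives a number no lower from compound 3 to compound 4 (the limit leaves the size open), so this ring with a hetero atom does not bring the number down in this place. Among the compounds shown here, compound 3 therefore remains the only member with an actual number, and compound 4 joins compound 1 and compound 2 at the assay limit. The steps joining compound 4 to compound 1 and to compound 2 cannot be read, because each runs between two limits: the limit of > 10 ug/mL in this assay, at which 3 of the 4 values shown sit.

From the compounds shown here alone, how far compound 1, compound 2 and compound 4 lie past that limit stays open, and so does the size of the step to compound 4. Also open, going by these compounds, is whether an aminomethyl group or a carboxylic acid on the phenyl ring would give a number rather than a limit.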